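The source may hold more compounds than are shown below. What is called first, only, known or untested is meant among the compounds shown, and "the series" means these compounds.

Of the compounds shown here, two have been tested in a functional assay on isolated protein for agonist activity at Glucose-dependent insulinotropic receptor (Rattus norvegicus), read by HTRF and cAMP accumulation; on this read-out higher numbers stand for larger maximal responses and lower numbers for smaller maximal responses. Compound 1, `CC(C)OC(=O)N1CCC(O[C@H]2CC[C@H](Oc3ccc(S(C)(=O)=O)nc3)CC2)CC1`, gives 125% in this assay. Compound 2, `CC1(OC(=O)N2CCC(O[C@H]3CC[C@H](Oc4cnc(S(C)(=O)=O)cn4)CC3)CC2)CC1`, gives 123% in this assay; this is the lower of the two numbers, yet the gap to compound 1 lies within the usual scatter, so the two cannot be told apart on this read-out. Compound 3, `CS(=O)(=O)c1cnc(O[C@H]2CC[C@H](OC3CCN(C(=O)C4(C(F)(F)F)CCCC4)CC3)CC2)cn1`, has not yet been measured. It differs from compound 2 in one place: a group of 9 heavy atoms (6 carbon, 3 fluorine; one five-membered non-aromatic ring of carbon only) in place of a group of 5 heavy atoms (4 carbon, 1 oxygen; one three-membered non-aromatic ring of carbon only), on a carbonyl carbon The entering group sits on a carbonyl carbon whose other neighbours are an amide-type nitrogen in a ring. Within the data shown here, no measured pair shows a change of this kind, so there is nothing to set its size against; all that is known is that the two measured maximal responses sit close together. The step expected from compound 2 to compound 3 is a number 8 percentage points lower from compound 2 to compound 3 (within the scatter), small and pointing slightly downward, not clearly beyond the scatter. Compound 3 is expected to give 115% in this assay, most likely between 90% and 135%.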

Compound 3, largest response reached (Emax), in percent of the reference or control that the assay uses: 124%
Estimate against measurement, compound 3: 9 percentage points below; measured number inside the range.
By their numbers in this assay, from the lowest: compounds 2, 3 and 1 (each within the scatter of the next).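

In this assay, putting a group of 9 heavy atoms, with a five-membered carbon ring and three fluorines, on the carbonyl carbon in place of (1-methylcyclopropyl)oxy gives a number 1 percentage points higher from compound 2 to compound 3 (within the scatter). This place therefore tolerates a clearly larger group without a detectable change in maximal response, even though the entering group counts no hydrogen-bond acceptor and the leaving group counts one. Nothing measured here explains why the response holds.

The compounds shown leave open whether the response would also hold with an amine, a longer chain or a carboxylic acid in this place, or with the same five-membered carbon ring carrying no fluorine. They also leave open how much of each compound is needed to reach its maximal response, which this read-out does not report.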